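Chloro Replaced by Amino on the Aromatic Ring

The source may hold more compounds than are shown below. What is called first, only, known or untested is meant among the compounds shown, and "the series" means these compounds.

Of the compounds shown here, three sharing one core have been measured in a functional assay (brain) for displacement of a labelled ligand, with Rattus norvegicus as the target; on this read-out lower numbers stand for stronger inhibition and higher numbers for weaker inhibition. Compound 1 `C[C@]1(c2ccccc2)OC[C@H]([C@@H]2CCCCN2)O1` gives 847 nM. Within the data shown here, compound 2 `CC(C)[C@]1(c2ccccc2)OC[C@H]([C@@H]2CCCCN2)O1` gives 45 nM, reached through the single measured step of a 19-fold lower number from compound 1 to compound 2 (1.27 log units; beyond the scatter), a change at a saturated ring carbon rather than on the aromatic ring. Compound 3 `CC[C@]1(c2cccc(Cl)c2)OC[C@H]([C@@H]2CCCCN2)O1` gives 59 nM; its number stands second highest of the three, close to that of compound 2 and within the scatter of it, while it lies far below the number of compound 1, well beyond the scatter.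

Compound 4 `CC[C@]1(c2cccc(N)c2)OC[C@H]([C@@H]2CCCCN2)O1` is not yet measured. It differs from compound 3 in one place: amino in place of chloro on an aromatic carbon. The group sits on an aromatic carbon of a six-membered aromatic ring of carbon only, meta to a large group.

Among the measured compounds shown here, no measured step touches the aromatic ring, so none bears directly on this change, and the expectation rests on the structural change alone. Compound 4 is expected to give about 150 nM, with a range from 50 nM to 500 nM. The expected step of a 2.5-fold higher number from compound 3 to compound 4 (0.41 log units; beyond the scatter) is estimated to be a modest weakening, not far beyond the scatter.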

Compound 4, inhibition constant: 1230 nM
Estimate against measurement, compound 4: 8.2-fold (0.91 log units) below; measured number outside the range, above it.
By their numbers in this assay, from the lowest: compounds 2 and 3 (each within the scatter of the next); then compounds 1 and 4 (each within the scatter of the next).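

In this assay, among these compounds, the amino-for-chloro change gives a 21-fold higher number from compound 3 to compound 4 (1.32 log units; beyond the scatter), the only measured step that touches the aromatic ring. Among the compounds shown here, this shows that the aromatic carbon meta to a large group is not indifferent to what it carries, as the earlier compounds could not reveal, since they offered no comparison at this position. The exchange swaps only one heavy atom for another, with amino bringing a hydrogen-bond donor and a hydrogen-bond acceptor that chloro lacks, yet the data given include nothing that explains why the number rises.

The compounds shown leave open whether the weakening reflects the loss of chloro or the arrival of amino, since a single swap changes both at once, and a plain hydrogen on this carbon would be the reference needed to separate the two. A methyl, a hydroxyl or a methoxy group at the same place would also help to show whether the step is specific to amino or extends to other groups.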